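Amine ring size on the thiocarbonyl carbon: working notes

The source may report more compounds than this note shows. Statements on the series, on what has been measured and on what is new or still open speak of the compounds shown alone.

Measured so far:
compound 1 `O=c1c(SC(=S)N2CCCC2)coc2ccc(Cl)cc12`, 16300 nM
compound 2 `O=c1c(SC(=S)N2CCCCC2)coc2ccc(Cl)cc12`, 8300 nM
compound 3 `COc1ccc2occ(CSC(=S)N3CCCC3)c(=O)c2c1`, 12100 nM

All three values come from a functional assay on HeLa cells (Homo sapiens) for antiproliferative activity, read by MTT assay, with a stated time of 72 h; a higher number here means a weaker inhibitor, a lower number a stronger inhibitor. Compound 1 and compound 2 share one core and differ in a single place: piperidin-1-yl in place of pyrrolidin-1-yl on a thiocarbonyl carbon. That step is a 2.0-fold lower number from compound 1 to compound 2 (0.29 log units; within the scatter). Compound 3 carries another core; how the core of compound 3 differs from the core of compound 1 is not broken down here, and the values of compound 1 and compound 3 lie within the scatter of each other, as do those of compound 3 and compound 2.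

Compound 4 `COc1ccc2occ(CSC(=S)N3CCCCC3)c(=O)c2c1` is not yet measured. It differs from compound 3 by piperidin-1-yl in place of pyrrolidin-1-yl on a thiocarbonyl carbon, the same kind of change as that from compound 1 to compound 2, made in the same place. Among the compounds with values here, for compound 4 the expected step in this assay is a 1.9-fold lower number from compound 3 to compound 4 (0.27 log units; within the scatter), resting only on the one earlier instance of this change, a 2.0-fold lower number from compound 1 to compound 2 (0.29 log units; within the scatter), since no second core has yet been tested with both amines. Compound 4 is therefore estimated at 6500 nM, with a range from 3000 nM to 14000 nM.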

Compound 4, half-maximal inhibitory concentration: 3500 nM
The estimate for compound 4 lay 1.9-fold (0.27 log units) above the measured number, and the stated range covers the measured number.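

In this assay, piperidin-1-yl in place of pyrrolidin-1-yl on a thiocarbonyl carbon gives a 3.5-fold lower number from compound 3 to compound 4 (0.54 log units; beyond the scatter) and, unlike the step on the core of compound 1, stands beyond the scatter. The change runs the same way on both cores, and the two steps cannot be told apart in size: the same change on two cores in this assay, a 2.0-fold lower number (0.29 log units; within the scatter) from compound 1 to compound 2 and a 3.5-fold lower number (0.54 log units; beyond the scatter) from compound 3 to compound 4, 1.8-fold (0.25 log units) apart, within the scatter of two such steps. This supports carrying the change from one of these cores to the other, but it rests on a single pair per core, shows no larger effect on the core of compound 3, and says nothing about cores beyond these two.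

The compounds shown leave open whether the trend in ring size goes on to a seven-membered azepane, and whether a morpholine or an open-chain dimethylamine on the thiocarbonyl carbon would fit with it. They also leave open which part of the difference between the two cores matters for antiproliferative activity in these cells.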